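The compounds below may be only part of what the source reports. "The series", "measured", "known", "first", "only" and "open" are said of these compounds alone.

Three compounds have been measured so far in a functional assay on HT-29 cells (Homo sapiens) for cytotoxicity, read by MTT assay, with a stated time of 72 h (on this read-out higher numbers stand for weaker inhibition and lower numbers for stronger inhibition), with these results:

Compound 1 `COc1ccc(NC(=O)CN2CCN(c3nnc(Cc4ccncc4)c4ccccc34)CC2)cc1OC` gives 40100 nM 
Compound 2 `Cc1ccc(NC(=O)CN2CCN(c3nnc(Cc4ccncc4)c4ccccc34)CC2)c(C)c1` gives 1930 nM 
Compound 3 `O=C(CN1CCN(c2nnc(Cc3ccccc3)c3ccccc23)CC1)Nc1ccc(F)c(F)c1` gives 9510 nM 

Compound 3, at 9510 nM here, stands second highest of the three numbers, with compound 1 higher and compound 2 lower, both gaps beyond the scatter. Compound 4 `O=C(CN1CCN(c2nnc(Cc3ccccc3)c3ccccc23)CC1)Nc1ccc(F)c(Cl)c1` differs from compound 3 by a single change (chloro in place of fluoro on an aromatic carbon), which turns 3,4-difluorophenyl into 3-chloro-4-fluorophenyl.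

Going by the values given here, only one measured step bears on this aryl group, and it is a large one: a 21-fold lower number from compound 1 to compound 2 (1.32 log units; beyond the scatter) for 2,4-dimethylphenyl in place of 3,4-dimethoxyphenyl. That step shows the group can move the number widely. However, it exchanges two groups, and compound 1 and compound 2 also differ from compound 3 elsewhere. Among the compounds with values here, no measured step covers chloro in place of fluoro.

The expected step in this assay is therefore small, estimated as a 1.4-fold lower number from compound 3 to compound 4 (0.13 log units; within the scatter) and slightly downward at most. For compound 4 the expected value is 7000 nM (estimated range 2500 nM to 20000 nM).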

Compound 4, half-maximal inhibitory concentration: 13300 nM
Compound 4: middle estimate off by 1.9-fold (0.28 log units), on the low side; the measured number falls inside the stated range.
By their numbers in this assay, from the lowest: compound 2; then compounds 3 and 4 (each within the scatter of the next); then compound 1.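

In this assay, exchanging chloro for fluoro on this aromatic carbon, which is ortho to a fluoro group and meta to a large group, gives a 1.4-fold higher number from compound 3 to compound 4 (0.15 log units; within the scatter). Although the aryl group can carry a step as wide as a 21-fold lower number from compound 1 to compound 2 (1.32 log units; beyond the scatter), this single-atom exchange leaves 3,4-difluorophenyl and 3-chloro-4-fluorophenyl indistinguishable on this read-out, so the position accepts either halogen without a readable difference. No available measurement accounts for this result.

The compounds shown leave open whether a bromo group, a nitrile or an amine on the same carbon would also stay within the scatter of compound 3. They also leave open whether chloro in place of fluoro would read the same on the core of compound 2.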